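A Smaller Ester Tail and the Expected Growth Inhibition

The compounds below may be only part of what the source reports. "The series", "measured", "known", "first", "only" and "open" are said of these compounds alone.

Measured so far:
compound 1, `C=CCOC(=O)c1ccsc1NC(=O)[C@@H]1CCCN1`, 96.6 ug/mL
compound 2, `O=C1CC[C@@H](COC(=O)c2ccsc2NC(=O)[C@@H]2CCCN2)N1`, 148 ug/mL

In a functional assay on MCF7 cells (Homo sapiens) for inhibition (on this read-out lower numbers stand for stronger inhibition of growth and higher numbers for weaker inhibition of growth), compound 2 gives the highest of the two numbers, and its nearest neighbour sits within the scatter: a 1.5-fold higher number from compound 1 to compound 2 (0.19 log units; within the scatter). Compound 3, `O=C(OCC(F)(F)F)c1ccsc1NC(=O)[C@@H]1CCCN1`, differs from compound 2 by trifluoromethyl in place of 5-oxopyrrolidin-2-yl on a saturated chain carbon bound to an oxygen next to a carbonyl group. Among the measured compounds shown here, only one measured step touches this position, a 1.5-fold higher number from compound 1 to compound 2 (0.19 log units; within the scatter), and it stayed within the scatter, so no step beyond the scatter is expected in this assay for compound 3. Compound 3 is estimated at 120 ug/mL, in a range from 50 ug/mL to 300 ug/mL. That estimate means an expected step of a 1.2-fold lower number from compound 2 to compound 3 (0.09 log units; within the scatter), within the scatter.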

Compound 3, concentration for 50% growth inhibition: 89.7 ug/mL
Compound 3: middle estimate off by 1.3-fold (0.13 log units), on the high side, within the range that was stated.
By their numbers in this assay, from the lowest: compounds 3, 1 and 2 (each within the scatter of the next).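

The steps of a 1.6-fold lower number from compound 2 to compound 3 (0.22 log units; within the scatter) and a 1.1-fold lower number from compound 1 to compound 3 (0.03 log units; within the scatter) in this assay show that trifluoromethyl, with no ring and no hydrogen-bond donor, stays within the scatter of both earlier groups. Vinyl, 5-oxopyrrolidin-2-yl and trifluoromethyl on a saturated chain carbon bound to an oxygen next to a carbonyl group have therefore given no step beyond the scatter. Nothing measured here explains this flat result. An amine, a carboxylic acid or a longer chain at this position remains an open case, as do changes elsewhere on the shared core.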